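Series notes: the step from compound 3 to compound 4

The compounds below may be only part of what the source reports. "The series", "measured", "known", "first", "only" and "open" are said of these compounds alone.

Measured so far:
Compound 1 `COc1cc(N)c(Cl)cc1NC(=O)C1CCN(Cc2ccc([N+](=O)[O-])cc2)CC1`: in a functional assay on the whole organism for antagonist activity, with Mus musculus as the target (on this read-out lower numbers stand for an effect already at smaller amounts and higher numbers for an effect only at larger amounts of compound), compound 1 gives > 4 mg/kg, which is a limit of the assay.
Compound 2 `CCN1CCC(C(=O)Nc2cc(Cl)c(N)cc2OC)CC1`: in this assay compound 2 gives > 10 mg/kg, also a limit of the assay.
Compound 3 `COc1cc(N)c(Cl)cc1NC(=O)C1CCN(Cc2ccc(OCc3ccccc3)cc2)CC1`: in this assay compound 3 gives > 4 mg/kg, again a limit of the assay.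

Compound 3 therefore stands at the limit of > 4 mg/kg in this assay, at which 2 of the 3 values shown sit, and shares that position with compound 1, while compound 2 sits at the limit of > 10 mg/kg in this assay, at which 1 of the 3 values shown sits. Among the compounds with values here, none of the three results is a number, so no compound can be set above or below another. The measured steps are a step that the two limits leave unreadable from compound 1 to compound 2 and a step that the two limits leave unreadable from compound 1 to compound 3; both run between limits and carry no readable size.

Compound 4 `COc1cc(N)c(Cl)cc1NC(=O)C1CCN(Cc2ccccc2)CC1` differs from compound 3 by hydrogen in place of benzyloxy on an aromatic carbon. The step that touches the same aromatic carbon is a step that the two limits leave unreadable from compound 1 to compound 3, but it gives no size and no direction. No change beyond the scatter can be expected from the data. The step that the limit leaves unreadable from compound 3 to compound 4 is therefore estimated as close to none. Compound 4 is expected at 8 mg/kg, between 3 mg/kg and 30 mg/kg, most likely reported once more only as a limit.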

Compound 4, dose for half-maximal effect: 0.5 mg/kg
Compound 4: the middle estimate sits 16-fold (1.20 log units) above what was measured; measured number below the stated range.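

In this assay, the aromatic carbon that carries the changing group gives the series its first readable steps: hydrogen in place of benzyloxy gives an at least 8.0-fold lower number from compound 3 to compound 4 (0.90 log units; beyond the scatter), and hydrogen in place of nitro gives an at least 8.0-fold lower number from compound 1 to compound 4 (0.90 log units; beyond the scatter). Phenyl in place of methyl on the saturated chain carbon bound to the amine nitrogen in a ring gives an at least 20-fold lower number from compound 2 to compound 4 (1.30 log units; beyond the scatter), yet the phenyl ring alone does not carry this pattern, as compound 1 and compound 3 also hold an aromatic ring there and report only limits. The earlier steps cannot be read, and no measured property shown accounts for the new steps.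

On these data alone, it remains open whether a fluoro, methoxy or amine group on that aromatic carbon would keep the result of compound 4. As far as these compounds go, the effect of a longer chain carrying the phenyl ring also remains open.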